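Diethylamino to amino on the amide chain

A few compounds are considered here, and "the series" means these few. Any claim that something is new, unique, unknown or untested is made for them only; others in the source may bear on it.

In a functional assay on Caco-2 cells (Homo sapiens), read by MTT assay, with a stated time of 48 h (on this read-out lower numbers stand for stronger inhibition and higher numbers for weaker inhibition), compound 1 `CCN(CC)CCNC(=O)c1ccc(C(CC)(CC)c2ccc(OCC(=O)C(C)(C)C)c(C)c2)n1CC` gives 1600 nM, compound 2 `CCn1c(C(=O)NCCCN(C)C)ccc1C(CC)(CC)c1ccc(OCC(=O)C(C)(C)C)c(C)c1` gives 1400 nM and compound 3 `CCN(CC)CCNC(=O)c1ccc(C(CC)(CC)c2ccc(OCC(O)C(C)(C)C)c(C)c2)n1CC` gives 2310 nM. These three values lie within the scatter of one another, so compound 3 is not set apart from the other two. Compound 4 `CCn1c(C(=O)NCCN)ccc1C(CC)(CC)c1ccc(OCC(O)C(C)(C)C)c(C)c1` follows from compound 3 with the change amino in place of diethylamino on a saturated chain carbon, two bonds along the chain from an amide-type nitrogen.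

The closest measured step concerns the same chain end: a 1.1-fold lower number from compound 1 to compound 2 (0.06 log units; within the scatter), with (dimethylamino)methyl in place of diethylamino. The step of a 1.4-fold higher number from compound 1 to compound 3 (0.16 log units; within the scatter) concerns the 1-hydroxy-2,2-dimethylpropyl group instead and bears on this change only indirectly. Within the data shown here, both lie within the scatter, but no measured compound carries the amino group, so the range is kept wide. The expected change in this assay is a 1.1-fold lower number from compound 3 to compound 4 (0.02 log units; within the scatter), with no step beyond the scatter expected. For compound 4 the estimated value is 2200 nM, with an expected range of 900 nM to 5500 nM.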

Compound 4, half-maximal inhibitory concentration: 1000 nM
Compound 4: middle estimate off by 2.2-fold (0.34 log units), on the high side; low and high end bracket the measured number.
By their numbers in this assay, from the lowest: compounds 4, 2, 1 and 3 (each within the scatter of the next, the first and the last beyond it).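

In this assay, amino in place of diethylamino on a saturated chain carbon, two bonds along the chain from an amide-type nitrogen, gives a modest step (a 2.3-fold lower number from compound 3 to compound 4 (0.36 log units; beyond the scatter)). Unlike the earlier steps (a 1.1-fold lower number from compound 1 to compound 2 (0.06 log units; within the scatter)) and (a 1.4-fold higher number from compound 1 to compound 3 (0.16 log units; within the scatter)), which stay within the scatter, this one lies beyond it, so a change at this chain end can move the number in this series. Nothing available here bears on the origin of this step.

Going by these compounds, whether the step carries over to the (tert-butyl)carbonyl compounds remains open, as it is read only with the 1-hydroxy-2,2-dimethylpropyl group in place. Also open, on these data alone, is how methylamino, a carboxylic acid or a longer chain ending in amino would read at this chain end.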